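Sulfonamide series: trifluoromethyl for methyl, cytotoxicity outlook

The source may hold more compounds than are shown below. What is called first, only, known or untested is meant among the compounds shown, and "the series" means these compounds.

Measured compounds:
compound 1 `O=S(=O)(Nc1ccc2oc(-c3ccccc3)nc2c1)c1ccccc1O`: 33000 nM
compound 2 `O=S(=O)(Nc1ccc2oc(-c3ccccc3)nc2c1)c1ccc(Cl)c(Cl)c1`: 71000 nM
compound 3 `Cc1ccccc1S(=O)(=O)Nc1ccc2oc(-c3ccccc3)nc2c1`: 57000 nM

In an ADME assay on HEK293 cells (Homo sapiens) for cytotoxicity, read by resazurin assay, with a stated time of 48 h (on this read-out higher numbers stand for lower toxicity in this test and lower numbers for higher toxicity in this test), compound 3 stands second highest of the three numbers. Its nearest neighbour is compound 2, the step of a 1.2-fold lower number from compound 2 to compound 3 (0.10 log units; within the scatter) lying within the scatter, and its furthest is compound 1, the step of a 1.7-fold higher number from compound 1 to compound 3 (0.24 log units; within the scatter) also lying within the scatter. Going by the values given here, the only step beyond the scatter is a 2.2-fold higher number from compound 1 to compound 2 (0.33 log units; beyond the scatter), and it is modest.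

Compound 4 is `O=S(=O)(Nc1ccc2oc(-c3ccccc3)nc2c1)c1ccccc1C(F)(F)F`. The change from compound 3 is trifluoromethyl in place of methyl on an aromatic carbon. The step that bears most on it is a 1.7-fold higher number from compound 1 to compound 3 (0.24 log units; within the scatter), a swap at the same aromatic carbon that stayed within the scatter; the swaps of the whole ring on the sulfonyl sulfur, a 2.2-fold higher number from compound 1 to compound 2 (0.33 log units; beyond the scatter) and a 1.2-fold lower number from compound 2 to compound 3 (0.10 log units; within the scatter), moved the numbers little. No step beyond the scatter is therefore expected in this assay.

Compound 4 is expected to give about 60000 nM, with a range of 30000 nM to 120000 nM. The estimated step is a 1.1-fold higher number from compound 3 to compound 4 (0.02 log units; within the scatter), read as no change beyond the scatter.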

Compound 4, half-maximal cytotoxic concentration: 80000 nM
Beside the measured number, compound 4's estimate is 1.3-fold (0.12 log units) below it; the range from low to high includes it.
By their numbers in this assay, from the lowest: compounds 1, 3, 2 and 4 (each within the scatter of the next, the first and the last beyond it).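

In this assay this aromatic carbon takes trifluoromethyl, a group of more heavy atoms than methyl, with a 1.4-fold higher number from compound 3 to compound 4 (0.15 log units; within the scatter) and no step beyond the scatter. The same carbon now also gives a modest step beyond the scatter, with a 2.4-fold higher number from compound 1 to compound 4 (0.38 log units; beyond the scatter) for trifluoromethyl in place of hydroxy, whereas methyl in place of hydroxy stayed within it. No supporting measurement is available to explain either step.

As far as these compounds go, whether an amine, a carboxylic acid or a longer chain on this aromatic carbon would move the number beyond the scatter from compound 3 remains open. Also open, from the compounds shown here alone, is how trifluoromethyl would read on another carbon of the same ring, since all comparisons at this position rest on compounds 1, 3 and 4 alone.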